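The source may report more compounds than this note shows. Statements on the series, on what has been measured and on what is new or still open speak of the compounds shown alone.

Measured compounds and their values in a functional assay on T-24 cells (Homo sapiens) for cytotoxicity, read by colorimetric assay and MTT assay; a higher number here means a weaker inhibitor, a lower number a stronger inhibitor:

Compound 1, `COc1cccc2cc(-c3ccccc3)c(O)nc12`: 10000 nM
Compound 2, `COc1ccc(-c2cc3cccc(OC)c3nc2O)cc1`: 10000 nM
Compound 3, `COc1ccc(-c2cc3c(OC)cc(OC)cc3n(C)c2=O)cc1`: 10000 nM

The three measured compounds all sit at the same reading in this assay, and none of them is a weaker or stronger inhibitor than another at the digits shown. For the measured compounds named here, compound 3 stands level with compound 1 and with compound 2, so it belongs to a flat set in which no compound is separated from the others.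

Compound 4, `COc1ccc(-c2cc3c(OC)cc(OC)cc3n(CC#N)c2=O)cc1`, has not yet been measured. It differs from compound 3 in one place: cyano in place of hydrogen on a saturated chain carbon bound to an aromatic nitrogen.

Going by the values given here, only one measured step exists, no change at the digits printed from compound 1 to compound 2 (within the scatter), and that step put methoxy in place of hydrogen on an aromatic carbon, which is a different kind of change at a different kind of place. Among the compounds with values here, no measured pair shows what a cyano group on a saturated chain carbon bound to an aromatic nitrogen does here. Within the data shown here, the single step that is known was within the scatter, and the set as a whole is flat, so the expectation for compound 4 is a step of no change at the digits printed from compound 3 to compound 4 (within the scatter), that is, no change beyond the scatter. On that basis compound 4 is estimated at 10000 nM, with a range from 4000 nM to 25000 nM.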

Compound 4, half-maximal inhibitory concentration: 10000 nM
For compound 4 middle estimate and measured number coincide at the digits printed; measured number inside the range.
By their numbers in this assay, from the lowest: compounds 1, 2, 3 and 4 (each within the scatter of the next).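

In this assay, the swap of methyl to cyanomethyl, on a saturated chain carbon bound to an aromatic nitrogen, gave no change at the digits printed from compound 3 to compound 4 (within the scatter). For the compounds shown here, this is the first measured step at this position, as the only earlier step put methoxy on an aromatic carbon and so said nothing about this place. The added nitrile, with its triple bond and one hydrogen-bond acceptor, leaves compound 4 at 10000 nM, level with the other three compounds, and nothing measured here offers any explanation for this flat result.

A single step cannot say whether other groups at this position, such as an amine, a carboxylic acid or a longer chain, would also read level with compound 3 in this assay. With all four compounds level, the set also leaves open whether any change at all, here or elsewhere on the shared core, such as a chlorine on the phenyl ring in place of the methoxy group, would separate one compound from the others.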